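Tail changes on the shared core: compound 4 estimate

The compounds below may be only part of what the source reports. "The series", "measured", "known", "first", "only" and "open" are said of these compounds alone.

Measured in an assay on HEK293 cells for displacement of a labelled ligand from NPC1-like intracellular cholesterol transporter 1 (Homo sapiens); a lower number here means a stronger inhibitor, a higher number a weaker inhibitor:
compound 1 `CC(C)(C)c1ccc(C(=O)N2CCC3(CC2)C(=O)N(CC(=O)NCCC(=O)O)CN3c2ccccc2)cc1` — 11400 nM
compound 2 `CC(C)(C)OC(=O)NCC1CCCN(C(=O)CN2CN(c3ccccc3)C3(CCN(C(=O)c4ccc(C(C)(C)C)cc4)CC3)C2=O)C1` — 9500 nM
compound 3 `CC(C)(C)c1ccc(C(=O)N2CCC3(CC2)C(=O)N(CC(=O)NCCCNS(C)(=O)=O)CN3c2ccccc2)cc1` — 10400 nM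

Compound 3 stands second highest of the three numbers, but both compound 2 and compound 1 sit within the scatter of it, so no order among the three is read. For the measured compounds named here, the one step between compounds differing in a single place, a 1.1-fold lower number from compound 1 to compound 3 (0.04 log units; within the scatter), is within the scatter.

Compound 4 `CC(C)(C)c1ccc(C(=O)N2CCC3(CC2)C(=O)N(CC(=O)N2CCCC(C(N)=O)C2)CN3c2ccccc2)cc1` differs from compound 3 by 3-carbamoylpiperidin-1-yl in place of (3-(methanesulfonamido)propyl)amino on a carbonyl carbon. Going by the values given here, no measured step exchanges an open-chain amide tail for a ring amine on that carbonyl; compound 2 differs from compound 3 in more than one place, and the values of compound 2 and compound 3 lie within the scatter of each other. Among the compounds with values here, the only bearing evidence is therefore that the tail change seen so far, a 1.1-fold lower number from compound 1 to compound 3 (0.04 log units; within the scatter), moved nothing beyond the scatter.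

For compound 4 the expected step is a 1.0-fold lower number from compound 3 to compound 4 (0.02 log units; within the scatter), none beyond the scatter. Compound 4 is estimated at 10000 nM, with a range of 4000 nM to 25000 nM in this assay.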

Compound 4, half-maximal inhibitory concentration: 16900 nM
For compound 4 the middle estimate is 1.7-fold (0.23 log units) below the measured one; the range from low to high includes it.
By their numbers in this assay, from the lowest: compounds 2, 3, 1 and 4 (each within the scatter of the next).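

In this assay, on a carbonyl carbon whose other neighbour is a saturated chain carbon, a ring amine now stands in for open-chain amines: 3-carbamoylpiperidin-1-yl in place of (3-(methanesulfonamido)propyl)amino gives (a 1.6-fold higher number from compound 3 to compound 4 (0.21 log units; within the scatter)), and in place of (2-carboxyethyl)amino gives (a 1.5-fold higher number from compound 1 to compound 4 (0.17 log units; within the scatter)). Within the ring-amine tails, carbamoyl in place of ((tert-butoxycarbonyl)amino)methyl on a saturated ring carbon gives (a 1.8-fold higher number from compound 2 to compound 4 (0.25 log units; within the scatter)). This carbonyl therefore takes both open-chain and ring tails with no step beyond the scatter across these four compounds, and nothing measured offers an explanation for the result.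

Open, going by these compounds, is whether a primary amine or a carboxylic acid on that saturated ring carbon, or a longer chain on the carbonyl carbon, would give a step beyond the scatter. The compounds shown do not tell whether the number depends on this tail at all.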